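From dimethylamino to bromo on compound 1

A few compounds are considered here, and "the series" means these few. Any claim that something is new, unique, unknown or untested is made for them only; others in the source may bear on it.

Compound 1 (`Cc1c(C(=O)N/N=C/c2ccc(N(C)C)cc2)no[n+]1[O-]`): 129000 nM
Compound 2 (`Cc1c(C(=O)N/N=C/c2ccc([N+](=O)[O-])o2)no[n+]1[O-]`): 96000 nM

Both numbers come from an ADME assay on J744 cells (Mus musculus) for cytotoxicity, read by MTT assay, with a stated time of 48 h (a higher number here means a weaker inhibitor, a lower number a stronger inhibitor), and lie within the usual scatter of each other, so compound 1 stands level with compound 2 and the two cannot be ranked. Compound 3 (`Cc1c(C(=O)N/N=C/c2ccc(Br)cc2)no[n+]1[O-]`) has not yet been measured. It keeps the core of compound 1 but carries bromo in place of dimethylamino on an aromatic carbon, on a six-membered aromatic ring of carbon only, para to a large group (bromo in place of dimethylamino on an aromatic carbon). Among the measured compounds shown here, no measured pair isolates this change in this assay and the data offer only an indirect guide. Compound 2 differs from compound 1 in more than one place, yet compound 2 (96000 nM) reads close to compound 1 (129000 nM). On that basis, no step beyond the scatter is expected, in either direction. The estimate amounts to a 1.3-fold lower number from compound 1 to compound 3 (0.11 log units; within the scatter) as the expected change. The estimated value for compound 3 is 100000 nM with an expected range from 40000 nM to 200000 nM as its two ends.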

Compound 3, half-maximal inhibitory concentration: 162000 nM
Compound 3: middle estimate off by 1.6-fold (0.21 log units), on the low side; low and high end bracket the measured number.
By their numbers in this assay, from the lowest: compounds 2, 1 and 3 (each within the scatter of the next).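

In this assay, among the compounds shown here, the exchange of dimethylamino for bromo gives a 1.3-fold higher number from compound 1 to compound 3 (0.10 log units; within the scatter) and is the first change in this set that can be read on its own. On an aromatic carbon of a six-membered aromatic ring of carbon only, para to a large group, the two groups therefore cannot be ranked, although dimethylamino has 3 heavy atoms and 1 hydrogen-bond acceptor, while bromo has 1 heavy atom and no hydrogen-bond acceptor. So at this place, neither the loss of that acceptor nor the difference in heavy atoms goes with a step beyond the scatter, and no measurement at hand offers an explanation for this result.

The compounds shown leave open whether a carboxylic acid, a primary amine or a longer alkyl chain at this place would move the number beyond the scatter, or would read level with dimethylamino and bromo. They also leave open whether the exchange of dimethylamino for bromo would read the same way on a core other than that of compound 1.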